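Swapping a Chloro for a Heptyloxy Chain

The source may hold more compounds than are shown below. What is called first, only, known or untested is meant among the compounds shown, and "the series" means these compounds.

Compound 1 `O=C(Nc1cccnc1)c1ccccc1OCc1cc(Cl)ccc1Cl`: 990 nM
Compound 2 `O=C(Nc1cccnc1)c1ccccc1OCc1cccc(Cl)c1F`: 3100 nM
Compound 3 `Cc1cccc(C)c1COc1ccccc1C(=O)Nc1cccnc1`: 890 nM

These three compounds share one core and differ only in the aromatic ring attached through the oxygen-linked saturated carbon. In an assay on lysate for inhibition of phosphatidylcholine:ceramide cholinephosphotransferase 2 (Homo sapiens), read by HPLC, with stated times of 30 min and 2 h (a lower number here means a stronger inhibitor, a higher number a weaker inhibitor), compound 1 gives 990 nM, the second highest of the three numbers. Compound 3, nearest to it, gives 890 nM, a gap within the scatter. Compound 2 gives 3100 nM; the step of a 3.1-fold higher number from compound 1 to compound 2 (0.50 log units; beyond the scatter) lies beyond the scatter.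

Compound 4 `CCCCCCCOc1ccc(Cl)cc1COc1ccccc1C(=O)Nc1cccnc1` differs from compound 1 by heptyloxy in place of chloro on an aromatic carbon, ortho to a large group and para to a chloro group. Within the data shown here, none of the measured steps adds a chain; they only rearrange small substituents, as in a 1.1-fold lower number from compound 1 to compound 3 (0.05 log units; within the scatter) and a 3.5-fold lower number from compound 2 to compound 3 (0.54 log units; beyond the scatter), so they bear on this change only loosely. No step beyond the scatter in this assay is therefore expected. Compound 4 is estimated at 900 nM, between 250 nM and 3500 nM, meaning a 1.1-fold lower number from compound 1 to compound 4 (0.04 log units; within the scatter).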

Compound 4, half-maximal inhibitory concentration: 430 nM
Compound 4: middle estimate off by 2.1-fold (0.32 log units), on the high side; low and high end bracket the measured number.
By their numbers in this assay, from the lowest: compound 4; then compounds 3 and 1 (each within the scatter of the next); then compound 2.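

The position bearing the chloro group in compound 1, ortho to a large group and para to a chloro group, accepts far more than a small substituent. In this assay, heptyloxy in place of chloro gives a 2.3-fold lower number from compound 1 to compound 4 (0.36 log units; beyond the scatter), so the inhibitor keeps its activity and gains a modest amount despite the much larger group. Nothing available here explains why the number falls.

As far as these compounds go, how much of this gain depends on chain length remains open. Methoxy, a longer chain such as decyloxy, or a heptyl chain ending in an amine could each compare differently at this position.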